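Halogen swap on the aryl ketone: fluoro to bromo

This account rests on a few compounds, and the source may have more. Where it says the series, first, only, none or still open, it means among the compounds named here.

Compound 1, `COc1cc(-c2nnc(SCC(=O)c3ccc(Cl)cc3)n2N2C(=O)c3ccccc3C2=O)cc(OC)c1OC`: 22000 nM
Compound 2, `COc1cc(-c2nnc(SCC(=O)c3ccc(F)cc3)n2N2C(=O)c3ccccc3C2=O)cc(OC)c1OC`: > 200000 nM

The two measured compounds share one core and differ only in the halogen on the aryl ketone. In a functional assay on HepG2 cells (Homo sapiens) for cytotoxicity, read by MTT assay, with a stated time of 48 h (a lower number here means a stronger inhibitor, a higher number a weaker inhibitor), compound 1 gives 22000 nM. Compound 2 reaches only the limit of this assay, > 200000 nM, so no number is known for it. Compound 2 therefore sits at the weak end of what has been measured; the step of an at least 9.0-fold higher number from compound 1 to compound 2 (0.95 log units; beyond the scatter) is a real loss, and how large a loss cannot be said because of the limit of > 200000 nM in this assay, at which 1 of the 2 values shown sits.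

Compound 3, `COc1cc(-c2nnc(SCC(=O)c3ccc(Br)cc3)n2N2C(=O)c3ccccc3C2=O)cc(OC)c1OC`, is the next step: bromo in place of fluoro on an aromatic carbon. For the measured compounds named here, one measured step bears on it, an at least 9.0-fold higher number from compound 1 to compound 2 (0.95 log units; beyond the scatter), where fluoro in place of chloro weakened the compound. Reversing that direction, the step is expected to be an at least 10-fold lower number from compound 2 to compound 3 (1.00 log units; beyond the scatter), a clear gain in potency. Compound 3 is estimated at 20000 nM, in the range 7000 nM to 80000 nM.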

Compound 3, half-maximal inhibitory concentration: 27700 nM
Compound 3: the middle estimate sits 1.4-fold (0.14 log units) below what was measured, and the stated range covers the measured number.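

Bromo at this place on the ring behaves like chloro and not like fluoro: in this assay there is an at least 7.2-fold lower number from compound 2 to compound 3 (0.85 log units; beyond the scatter), and beside it a 1.3-fold higher number from compound 1 to compound 3 (0.10 log units; within the scatter). The earlier pair showed only that fluoro fell short of chloro, whereas among these three halogens the loss now belongs to fluoro alone, with chloro and bromo indistinguishable. The value of compound 2, > 200000 nM, is a limit of the assay and not a number, so the full size of the gain on going to bromo stays unknown: the limit of > 200000 nM in this assay, at which 1 of the 3 values shown sits.

Still open, as far as these compounds go, is whether iodo would match chloro and bromo, and whether a plain hydrogen would fall with fluoro. Also open, from the compounds shown here alone, is what a group of another kind, such as an amine or a nitrile, would do on this ring.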